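This account rests on a few compounds, and the source may have more. Where it says the series, first, only, none or still open, it means among the compounds named here.

Compound 1 `Cc1cc(NC(=O)c2ccc(Cl)cc2)ccc1NS(C)(=O)=O` gives 69100 nM in an ADME assay on RAW264.7 cells (Mus musculus) for cytotoxicity, read by MTT assay, with a stated time of 48 h; a higher number here means a weaker inhibitor, a lower number a stronger inhibitor; compound 2 `Cc1cc(NC(=O)c2ccc(C#N)cc2)ccc1NS(C)(=O)=O` gives 171000 nM; compound 3 `Cc1cc(NC(=O)c2ccc(C#N)cc2)ccc1NS(=O)(=O)C(F)(F)F` gives 135000 nM.

Compound 2 holds the highest of the three numbers in this assay. Compound 3 lies nearest, and the step of a 1.3-fold lower number from compound 2 to compound 3 (0.10 log units; within the scatter) is within the scatter, while compound 1 lies furthest, with a 2.5-fold higher number from compound 1 to compound 2 (0.39 log units; beyond the scatter). Compound 4 `CS(=O)(=O)Nc1ccc(NC(=O)c2ccc(C#N)cc2)cc1F` differs from compound 2 by fluoro in place of methyl on an aromatic carbon. Neither measured step concerns this kind of change: one swaps a group on the benzoyl ring, the other alters the group on the sulfonyl sulfur. Among the measured compounds shown here, the data hold no step of the same kind, so no shift beyond the scatter is expected, and the estimated step is a 1.1-fold lower number from compound 2 to compound 4 (0.06 log units; within the scatter). Compound 4 is therefore expected to give 150000 nM, between 70000 nM and 300000 nM.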

Compound 4, half-maximal inhibitory concentration: > 250000 nM
Compound 4: a limit, no number; the forecaster's own chance of this, stated with the estimate: 15%; middle value at least 1.6-fold (0.22 log units) away from the limit.
By their numbers in this assay, from the lowest: compounds 1, 3 and 2 (each within the scatter of the next, the first and the last beyond it). At a limit, above all of these: compound 4.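

In this assay compound 4 gives a limit, not a number: the limit of > 250000 nM in this assay, at which 1 of the 4 values shown sits. Fluoro in place of methyl, ortho to a methanesulfonamido group, is the first change at this position, and it reads as an at least 1.4-fold higher number from compound 2 to compound 4 (0.16 log units; that floor lies within the scatter). From the compounds shown here alone, that floor alone does not set the two compounds apart, though the change does not bring the number down, and the true size of the step stays unknown.

The compounds shown leave open how a methoxy group or an amine would read at this position. They also leave open whether fluoro here gives the same result alongside the trifluoromethyl on the sulfonyl sulfur of compound 3.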